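The source may report more compounds than this note shows. Statements on the series, on what has been measured and on what is new or still open speak of the compounds shown alone.

Measured so far:

compound 1, `CCOC(=O)C1=C(N/N=C(\c2ccc([N+](=O)[O-])cc2)N2CCN(c3ccc(F)cc3)CC2)Nc2[nH]nc(C)c2C1c1ccc(N(C)C)cc1` — 90200 nM
compound 2, `CCOC(=O)C1=C(N/N=C(/Cl)C#N)Nc2[nH]nc(C)c2C1c1ccc(N(C)C)cc1` — 23600 nM

Both compounds were run in a functional assay on HepG2 cells (Homo sapiens) for inhibition, read by MTT assay, with a stated time of 48 h; on this read-out lower numbers stand for stronger inhibition and higher numbers for weaker inhibition. Compound 1 gives 90200 nM and compound 2 gives 23600 nM. Compound 2 thus carries the lower of the two numbers, and its gap to compound 1 lies beyond the usual scatter of this assay, so compound 2 counts as the stronger inhibitor of the pair. No single-point comparison between measured compounds is available, so nothing can yet be said about how a change at the amine nitrogen on this shared core moves the read-out.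

The next compound in the series is compound 3, `CCOC(=O)C1=C(N/N=C(/C#N)C(=O)OCC)Nc2[nH]nc(C)c2C1c1ccc(N(C)C)cc1`. Compared with compound 2 it differs as follows: a group of 9 heavy atoms (5 carbon, 2 nitrogen, 2 oxygen; no ring) in place of a group of 5 heavy atoms (2 carbon, 2 nitrogen, 1 chlorine; no ring), on an amine nitrogen. Without a measured step of related kind, the expectation for this change is a shift of no more than the scatter in either direction, since both groups sit on the same amine nitrogen and neither ring nor charge changes. Compound 3 is therefore expected to give an estimated 30000 nM in this assay, with a likely range from 8000 nM to 110000 nM. This estimate means a step of a 1.3-fold higher number from compound 2 to compound 3 (0.10 log units; within the scatter), expected to stay within the scatter.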

Compound 3, half-maximal inhibitory concentration: 46400 nM
Compound 3: the middle estimate sits 1.5-fold (0.19 log units) below what was measured, and the stated range covers the measured number.
By their numbers in this assay, from the lowest: compounds 2, 3 and 1 (each within the scatter of the next, the first and the last beyond it).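

In this assay, for the compounds shown here, the exchange on an amine nitrogen whose other neighbours are double-bonded ring carbon gives a 2.0-fold higher number from compound 2 to compound 3 (0.29 log units; within the scatter), the first comparison that can be read at this position. The entering group has 9 heavy atoms and 4 hydrogen-bond acceptors and contains no chlorine, while the leaving group has 5 heavy atoms and 2 hydrogen-bond acceptors, so in this pair a change of this size and atom make-up leaves the read-out within the scatter. Nothing measured on these compounds offers a cause for this result.

Going by these compounds alone, this single step cannot separate the contribution of the chlorine from that of the added oxygen-bearing atoms, and no step linking compound 1 to compound 2 or compound 3 can be read. On these data alone, how a carboxylic acid, a primary amide, a simple amine or a longer chain at this position would behave in this assay remains open, including whether any such group would move the read-out beyond the scatter in either direction.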